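The source may report more compounds than this note shows. Statements on the series, on what has been measured and on what is new or still open speak of the compounds shown alone.

Measured in a functional assay on A-375 cells (Homo sapiens) for antiproliferative activity, read by CCK-8 assay, with a stated time of 72 h, tested at 2 uM; a higher number here means a stronger effect of the compound at the concentration tested, a lower number a weaker effect:
compound 1 `Nc1ccccc1NC(=O)c1ccc(CSC(=S)N2CCN(c3ccccc3)CC2)cc1`, 27.5%
compound 2 `Nc1ccccc1NC(=O)c1ccc(CSC(=S)N2CCc3ccccc32)cc1`, 25.7%
compound 3 `Nc1ccccc1NC(=O)c1ccc(CSC(=S)N2CCN(c3ccc(F)cc3)CC2)cc1`, 20.9%

Compound 2 stands second of the three numbers. Its nearest neighbour is compound 1 and its furthest compound 3, and both gaps lie within the scatter, so no order among the three is claimed; the whole set occupies a narrow band in this assay.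

Among the compounds with values here, only one step between measured compounds that differ in a single place is available: a number 6.6 percentage points lower from compound 1 to compound 3 (within the scatter). That step, a fluoro in place of hydrogen on an aromatic carbon, lies within the scatter.

Compound 4 `CC1CCCCN1C(=S)SCc1ccc(C(=O)Nc2ccccc2N)cc1` is not yet measured. It differs from compound 2 as follows: 2-methylpiperidin-1-yl in place of 2,3-dihydro-1H-indol-1-yl on a thiocarbonyl carbon. Within the data shown here, no measured step exchanges the whole group on the thiocarbonyl carbon, so the measured step above bears on the new compound only loosely, as a sign that the numbers in this assay have so far moved little. The step from compound 2 to compound 4 is therefore expected to stay within the scatter, a number 0.7 percentage points lower from compound 2 to compound 4 (within the scatter). Compound 4 is estimated at 25%, with a range from 14% to 36%.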

Compound 4, a percentage reported as inhibition, at one concentration (the size of the read-out at that concentration, not a potency): 42.5%
Compound 4: the middle estimate sits 17.5 percentage points below what was measured; measured number above the stated range.
By their numbers in this assay, from the lowest: compounds 3, 2 and 1 (each within the scatter of the next); then compound 4.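

On the thiocarbonyl carbon, exchange of the whole group moves the read-out in this assay beyond the scatter, with a number 16.8 percentage points higher from compound 2 to compound 4 (beyond the scatter) when 2-methylpiperidin-1-yl replaces 2,3-dihydro-1H-indol-1-yl. This is the only step shown that exceeds the scatter, whereas the fluoro exchange on an aromatic carbon did not, so the group on the thiocarbonyl carbon is a place where this series responds measurably. The entering group has one six-membered non-aromatic ring, no aromatic ring and fewer heavy atoms, but no available evidence connects the higher number with any of these differences.

The compounds shown leave open whether the gain goes with the methyl group or with the non-aromatic ring alone, which an unsubstituted piperidin-1-yl would address. Also open, from the compounds shown here alone, is whether morpholin-4-yl, with an oxygen in that ring, or an ethyl group in place of the methyl would hold the number.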